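Benzylamine swap on the shared core: dichloro to methoxy

This account rests on a few compounds, and the source may have more. Where it says the series, first, only, none or still open, it means among the compounds named here.

Compound 1 `Nc1cc(N)c2nc(-c3ccccc3)c(NCc3ccc(Cl)c(Cl)c3)nc2c1` is the anchor of this short set. Among the measured compounds shown here, in a functional assay on SF-268 cells (Homo sapiens) for inhibition, read by sulforhodamine B assay, with a stated time of 48 h (a higher number here means a weaker inhibitor of growth, a lower number a stronger inhibitor of growth), compound 1 gives 55000 nM, the only number the set holds. Compound 2 `CCOC(=O)[C@H](CCC(=O)O)NC(=O)c1ccc(Oc2nc3cc(N)cc(N)c3nc2-c2ccccc2)cc1` is the other member, and in this assay compound 2 is recorded only as a limit, < 100000 nM. That limit, (the limit of < 100000 nM in this assay, at which 1 of the 2 values shown sits), supplies no number to compare. For the measured compounds named here, no step between measured compounds is available, so compound 3 is judged from compound 1 alone. Compound 3 `COc1ccc(CNc2nc3cc(N)cc(N)c3nc2-c2ccccc2)cc1` carries 4-methoxyphenyl in place of 3,4-dichlorophenyl on a saturated chain carbon bound to a nitrogen on an aromatic ring. Going by the values given here, with no measured step to lean on, the expected step from compound 1 to compound 3 is a 1.3-fold higher number from compound 1 to compound 3 (0.10 log units; within the scatter), a small loss that may well sit inside the scatter, with a real chance that the read-out comes back as a limit rather than a number. In this assay compound 3 is estimated at 70000 nM, between 25000 nM and 150000 nM.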

Compound 3, concentration for total growth inhibition: 21900 nM
The estimate for compound 3 lay 3.2-fold (0.50 log units) above the measured number; measured number below the stated range.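

The position on the saturated chain carbon bound to a nitrogen on an aromatic ring tolerates a full change of ring substituents. In this assay, among the compounds shown here, the swap of 3,4-dichlorobenzyl to 4-methoxybenzyl gives a 2.5-fold lower number from compound 1 to compound 3 (0.40 log units; beyond the scatter) and is the first readable step in this set. Chlorine on this ring is therefore not required to hold this level of growth inhibition, and the methoxy-bearing ring does modestly better; nothing measured here accounts for the size of the step.

From the compounds shown here alone, the swap removes both chlorines and introduces the methoxy group in one change, so the share of each in the step remains open. An unsubstituted benzyl or a 4-chlorobenzyl group on the same chain carbon would separate the two contributions.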